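This account rests on a few compounds, and the source may have more. Where it says the series, first, only, none or still open, it means among the compounds named here.

Measured so far in a functional assay on K562 cells (Homo sapiens) for cytotoxicity, read by trypan blue exclusion, with a stated time of 96 h; on this read-out lower numbers stand for stronger inhibition and higher numbers for weaker inhibition:
- compound 1, `COc1ccc(CS(=O)(=O)/C=C/c2c(OC)cccc2OC)cc1[N+](=O)[O-]`: 20000 nM
- compound 2, `COc1ccc(CS(=O)(=O)/C=C/c2c(OC)cccc2OC)cc1N`: 50 nM
- compound 3, `COc1cc(OC)c(/C=C/S(=O)(=O)Cc2ccc(OC)cc2[N+](=O)[O-])c(OC)c1`: 20000 nM

Compound 2 is obtained from compound 1 by the change (amino in place of nitro on an aromatic carbon). Going by the values given here, this one change gives a 400-fold lower number from compound 1 to compound 2 (2.60 log units; beyond the scatter), the only step in the set so far.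

Compound 3 stands level with compound 1 at the digits read. The difference between the core of compound 3 and the core of compound 1 is not broken down here.

Compound 4, `COc1ccc(CS(=O)(=O)/C=C/c2c(OC)cc(OC)cc2OC)c(N)c1`, is not yet measured. It is obtained from compound 3 by amino in place of nitro on an aromatic carbon. This is the same kind of change as that from compound 1 to compound 2, but not the same: in compound 2 the entering amino sits ortho to a methoxy group and meta to a large group, whereas in compound 4 it sits ortho to a large group and meta to a methoxy group.

Even so, a step of similar direction and size is expected for compound 4 in this assay, namely a 200-fold lower number from compound 3 to compound 4 (2.30 log units; beyond the scatter), because a 400-fold lower number from compound 1 to compound 2 (2.60 log units; beyond the scatter) was seen for the one earlier instance of this kind of change. Compound 4 is therefore estimated at 100 nM, with the range 30 nM to 1000 nM reflecting that the surroundings of the changed carbon are not identical.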

Compound 4, half-maximal inhibitory concentration: 25 nM
The estimate for compound 4 lay 4.0-fold (0.60 log units) above the measured number; the whole stated range lies above it.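

In this assay, amino in place of nitro on an aromatic carbon carries over to the second core, giving an 800-fold lower number from compound 3 to compound 4 (2.90 log units; beyond the scatter). The two instances agree in direction, and their sizes do not differ beyond the scatter: the same change on two cores in this assay, a 400-fold lower number (2.60 log units; beyond the scatter) from compound 1 to compound 2 and an 800-fold lower number (2.90 log units; beyond the scatter) from compound 3 to compound 4, 2.0-fold (0.30 log units) apart, within the scatter of two such steps. This supports carrying the change between these two cores, but with only two instances it says nothing about a core outside them, nor does it explain why the change has so large an effect.

The compounds shown leave open whether a group other than amino on the same aromatic carbon, such as hydroxyl, acetamide or dimethylamino, would also give a low number, or whether the step belongs to the amino group alone. Also open, on these data alone, is whether a step of this size would appear with the methoxy groups on either aromatic ring replaced, for example by ethoxy or fluorine, or in any read-out other than this assay.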